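Changing one aryl group on compound 1

The compounds below may be only part of what the source reports. "The series", "measured", "known", "first", "only" and "open" are said of these compounds alone.

For the measured compounds named here, in a functional assay on NIH3T3 cells (Mus musculus) (on this read-out lower numbers stand for an effect already at smaller amounts and higher numbers for an effect only at larger amounts of compound), compound 1 (`Cn1cncc1C(OCc1ccc(C#N)cc1-c1ccc(F)c(Cl)c1)c1ccc(C#N)nc1`) gives 46 nM, the highest of the three numbers measured so far. Compound 2 (`Cn1cncc1C(OCc1ccc(C#N)nc1-c1ccccc1)c1ccc(C#N)cc1`) gives 19 nM and compound 3 (`CN1CCN(c2nc(COC(c3ccc(C#N)cc3)c3cncn3C)c(-c3cccc(Cl)c3)cc2C#N)CC1`) gives 2 nM, and both numbers lie lower than that of compound 1 by more than the usual scatter of repeated measurements. Neither of them differs from compound 1 in just one place, so they say little about the change considered here.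

That change leads to compound 4 (`Cn1cncc1C(OCc1ccc(C#N)cc1-c1cccc(OC(F)(F)F)c1)c1ccc(C#N)nc1`), which keeps the core of compound 1 and carries 3-(trifluoromethoxy)phenyl in place of 3-chloro-4-fluorophenyl on an aromatic carbon, ortho to a large group and meta to a cyano group (3-(trifluoromethoxy)phenyl in place of 3-chloro-4-fluorophenyl on an aromatic carbon). Both groups are built on one six-membered aromatic ring of carbon only, so the ring stays and only what it carries changes. Going by the values given here, no measured pair shows a swap of this kind. With only the value of compound 1 (46 nM) to start from, no step beyond the scatter is expected in this assay, and the estimated step is small (a 1.2-fold lower number from compound 1 to compound 4 (0.06 log units; within the scatter)). The expected value for compound 4 is (40 nM), within an estimated range (14 nM to 115 nM).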

Compound 4, half-maximal effective concentration: 24 nM
Compound 4: middle estimate off by 1.7-fold (0.22 log units), on the high side, within the range that was stated.
By their numbers in this assay, from the lowest: compound 3; then compounds 2, 4 and 1 (each within the scatter of the next, the first and the last beyond it).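

For the compounds shown here, this is the first step here between two compounds that differ in one place: in this assay, putting 3-(trifluoromethoxy)phenyl in place of 3-chloro-4-fluorophenyl gives a 1.9-fold lower number from compound 1 to compound 4 (0.28 log units; within the scatter). The position, on an aromatic carbon ortho to a large group and meta to a cyano group, therefore accepts a group with more heavy atoms and a hydrogen-bond acceptor that the old group lacks, and the read-out cannot be told apart from that of compound 1. Nothing at hand explains this outcome, so it stands as a plain observation.

Both groups in this pair are built on the same carbon-only aromatic ring, so the pair does not show how this position responds to a quite different substituent, such as a primary amine or a carboxylic acid placed there instead of the aryl ring. It also leaves open whether the same swap would read the same way on a different scaffold, such as that of compound 2 or compound 3.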